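The source may hold more compounds than are shown below. What is called first, only, known or untested is meant among the compounds shown, and "the series" means these compounds.

Values in a functional assay on the whole organism (Hindlimb, strain albino) with Mus musculus as the target, in the maximal electroshock model, with a stated time of 0.5 h; a lower number here means that less compound is needed, a higher number that more compound is needed for the effect:
- compound 1 `CC(=O)N1N=C(Nc2nc3ccc([N+](=O)[O-])cc3s2)CC1c1ccc(O)cc1`: 162 umol/kg
- compound 2 `CC(=O)N1N=C(Nc2nc3ccc(Cl)cc3s2)CC1c1ccc(O)cc1`: 106 umol/kg
- compound 3 `CC(=O)N1N=C(Nc2nc3ccccc3s2)CC1c1ccc(O)cc1`: 249 umol/kg

Compound 1 stands inside the narrow span of this set, and neither step leading from it leaves the scatter: a 1.5-fold lower number from compound 1 to compound 2 (0.18 log units; within the scatter) and a 1.5-fold higher number from compound 1 to compound 3 (0.19 log units; within the scatter). Among the measured compounds shown here, only one measured step goes beyond the scatter, and it is modest: a 2.3-fold higher number from compound 2 to compound 3 (0.37 log units; beyond the scatter).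

Compound 4 `CC(=O)N1N=C(Nc2nc3ccc([N+](=O)[O-])cc3s2)CC1OC1=CC=C1` has not yet been measured. The structural change is a group of 5 heavy atoms (4 carbon, 1 oxygen; one four-membered non-aromatic ring of carbon only) in place of a group of 7 heavy atoms (6 carbon, 1 oxygen; one six-membered aromatic ring of carbon only), on a saturated ring carbon. The 4-hydroxyphenyl group leaves, and the incoming group has no common name.

For the measured compounds named here, none of the measured steps touches this saturated ring carbon. All three swap nitro, chloro or hydrogen on an aromatic carbon, and all three compounds keep the 4-hydroxyphenyl group. They therefore show how tight the series is at another place, but they give no direction for this change. With no better guide, no shift beyond the scatter is expected in this assay, though confidence is low and the range must stay wide. The estimated change is a 1.1-fold higher number from compound 1 to compound 4 (0.05 log units; within the scatter). Compound 4 is expected at 180 umol/kg, with an estimated range of 70 umol/kg to 450 umol/kg.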

Compound 4, dose for half-maximal effect: 274 umol/kg
For compound 4 the middle estimate is 1.5-fold (0.18 log units) below the measured one, within the range that was stated.
By their numbers in this assay, from the lowest: compounds 2, 1, 3 and 4 (each within the scatter of the next, the first and the last beyond it).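

In this assay, the saturated ring carbon now has its first measured change, and the outcome is a 1.7-fold higher number from compound 1 to compound 4 (0.23 log units; within the scatter), a step that stays within the scatter even though it is the only one in the set made at this place. For this single pair, the 4-hydroxyphenyl group can therefore give way to a group with a four-membered non-aromatic ring, 2 double bonds outside aromatic rings and no hydrogen-bond donor, without the number leaving the scatter, so neither the six-membered aromatic ring nor the hydrogen-bond donor of the leaving group is shown to be required in this assay. No measurement at hand bears on why this exchange leaves the number within the scatter.

The pair changes ring and hydroxyl together, so the part played by each remains unresolved, and a plain phenyl group, an amine, a carboxylic acid or a longer chain on the same saturated ring carbon would test how far this tolerance extends. Among the compounds shown here, also open is whether the chloro and hydrogen steps on the aromatic carbon, seen only with the 4-hydroxyphenyl group in place, carry over to the group in compound 4.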